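The source may hold more compounds than are shown below. What is called first, only, known or untested is meant among the compounds shown, and "the series" means these compounds.

Measured in a functional assay on HCT-116 cells (Homo sapiens) for cytotoxicity, read by MTT assay, with a stated time of 48 h, tested at 15 uM; on this read-out lower numbers stand for a stronger effect and higher numbers for a weaker effect at the one concentration tested:
compound 1 `Cc1cccc(/C=C/C(=O)c2ccccc2O)c1`: 85.9%
compound 2 `O=C(/C=C/c1cccc(Cl)c1)c1ccccc1O`: 37.5%
compound 3 `COc1cccc(/C=C/C(=O)c2ccccc2O)c1O`: 84.7%

Compound 3 stands second highest of the three. Its nearest neighbour is compound 1, whose value lies within the scatter of that of compound 3; compound 2 lies far lower, beyond the scatter. Compound 4 `COc1cccc(/C=C/C(=O)c2ccccc2O)c1` differs from compound 3 by hydrogen in place of hydroxy on an aromatic carbon. Going by the values given here, the only one-place step measured, a number 48.4 percentage points lower from compound 1 to compound 2 (beyond the scatter), concerns a different change at a different position and does not bear on this one. Compounds 1 and 3 show that two distinct substituents give values within the scatter of each other, so no shift beyond the scatter is expected for compound 4, a number 2.7 percentage points lower from compound 3 to compound 4 (within the scatter). Compound 4 is estimated at 82%, range 62% to 96%.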

Compound 4, a percentage reported as activity, at one concentration (the size of the read-out at that concentration, not a potency): 89.6%
The estimate for compound 4 lay 7.6 percentage points below the measured number; low and high end bracket the measured number.
By their numbers in this assay, from the lowest: compound 2; then compounds 3, 1 and 4 (each within the scatter of the next).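

In this assay, hydrogen in place of hydroxy on the aromatic carbon ortho to a methoxy group leaves the read-out within the scatter (a number 4.9 percentage points higher from compound 3 to compound 4 (within the scatter)), so the hydroxy group counts for little here. On the methoxy-bearing carbon, methoxy in place of methyl also stays within the scatter (a number 3.7 percentage points higher from compound 1 to compound 4 (within the scatter)), while methoxy in place of chloro does not (a number 52.1 percentage points higher from compound 2 to compound 4 (beyond the scatter)); of the three groups there, only chloro stands apart.

As far as these compounds go, whether bromo or an amine at that carbon would read like chloro or like methoxy remains open. Nothing available explains why chloro stands apart.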